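Compound 3 to compound 4: swapping 1H-indol-3-yl for propyl

The source may report more compounds than this note shows. Statements on the series, on what has been measured and on what is new or still open speak of the compounds shown alone.

Of the compounds shown here, three sharing one core have been measured in a functional assay on A549 cells (Homo sapiens) for antiproliferative activity, read by MTT assay, with a stated time of 48 h; a higher number here means a weaker inhibitor, a lower number a stronger inhibitor. Compound 1 `Clc1cccc(Nc2ncnc3ccc(NCc4cccc(Br)n4)cc23)c1` gives 2950 nM, compound 2 `Clc1cccc(Nc2ncnc3ccc(NCc4ccc(Br)s4)cc23)c1` gives 820 nM and compound 3 `Clc1cccc(Nc2ncnc3ccc(NCc4c[nH]c5ccccc45)cc23)c1` gives 2330 nM. Compound 3 cannot be separated from compound 1 and stands above compound 2, which holds the lowest number of the three, with its steps to both others beyond the scatter.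

Compound 4 `CCCCNc1ccc2ncnc(Nc3cccc(Cl)c3)c2c1` carries propyl in place of 1H-indol-3-yl on a saturated chain carbon bound to a nitrogen on an aromatic ring.

The measured steps at this place all exchange one ring-bearing group for another. One is a 1.3-fold lower number from compound 1 to compound 3 (0.10 log units; within the scatter), and the two modest ones are a 3.6-fold lower number from compound 1 to compound 2 (0.56 log units; beyond the scatter) and a 2.8-fold higher number from compound 2 to compound 3 (0.45 log units; beyond the scatter). Among the measured compounds shown here, no measured compound has a group without a ring here, so these steps bear on the change only indirectly. For the measured compounds named here, the expectation in this assay is no step clearly beyond the scatter, with a weak lean towards a higher number that the data do not settle. The expected step is a 1.5-fold higher number from compound 3 to compound 4 (0.18 log units; within the scatter). Compound 4 is estimated at 3500 nM, with an expected range of 1200 nM to 10000 nM.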

Compound 4, half-maximal inhibitory concentration: 4010 nM
For compound 4 the middle estimate is 1.1-fold (0.06 log units) below the measured one; measured number inside the range.
By their numbers in this assay, from the lowest: compound 2; then compounds 3, 1 and 4 (each within the scatter of the next).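

In this assay, among the compounds shown here, propyl is the first group without a ring at this place, on a saturated chain carbon bound to a nitrogen on an aromatic ring, and it cannot be separated from two of the ring-bearing groups: a 1.7-fold higher number from compound 3 to compound 4 (0.24 log units; within the scatter) and a 1.4-fold higher number from compound 1 to compound 4 (0.13 log units; within the scatter). Among the four compounds, neither the two aromatic rings of 1H-indol-3-yl nor the single ring of 6-bromopyridin-2-yl gives a number separable from that of propyl, so a ring at this place is not needed to stay at this level, while 5-bromothiophen-2-yl alone stands apart, with a 4.9-fold higher number from compound 2 to compound 4 (0.69 log units; beyond the scatter). No measurement at hand explains why that group differs from the other three.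

The compounds shown leave open whether the lower number of compound 2 goes with the bromine or with the rest of 5-bromothiophen-2-yl, a question that thiophen-2-yl without bromine would address. Propyl is also the only group without a ring here, so the reading of a longer chain, or of a chain ending in an amine or a carboxylic acid, remains open.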